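Pyrazole methyl relocation in the biaryl amide series

The source may hold more compounds than are shown below. What is called first, only, known or untested is meant among the compounds shown, and "the series" means these compounds.

Going by the values given here, compound 1 `CC(C)Oc1cc(-c2cncc(-c3cnn(C)c3)c2)ccc1C(N)=O` gives 400 nM in an assay on cells for inhibition of MAP kinase-interacting serine/threonine-protein kinase 1 (Homo sapiens), read by mobility shift assay, with stated times of 10 min and 60 min, in the presence of a further agent that is not named here (on this read-out higher numbers stand for weaker inhibition and lower numbers for stronger inhibition), the lowest of the three numbers so far. Compound 2 `Cn1cc(-c2cncc(-c3ccc(C(N)=O)cc3)c2)cn1` gives 800 nM in this assay, and compound 3 `NC(=O)c1ccc(-c2cccnc2)cc1` gives 8800 nM. Among the compounds with values here, the step of a 2.0-fold higher number from compound 1 to compound 2 (0.30 log units; within the scatter) follows the removal of the isopropoxy group, whereas the step of an 11-fold higher number from compound 2 to compound 3 (1.04 log units; beyond the scatter) follows the removal of the 1-methyl-1H-pyrazol-4-yl group and is the only large step in the set.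

Compound 4 `Cc1[nH]ncc1-c1cncc(-c2ccc(C(N)=O)c(OC(C)C)c2)c1` differs from compound 1 by 5-methyl-1H-pyrazol-4-yl in place of 1-methyl-1H-pyrazol-4-yl on an aromatic carbon. Within the data shown here, no measured step changes the pyrazole in this way; the only related step, an 11-fold higher number from compound 2 to compound 3 (1.04 log units; beyond the scatter), shows that the pyrazole itself matters, while the present change keeps a pyrazole in place and moves only the methyl. On that basis no step beyond the scatter is expected for compound 4 in this assay, the expected step being no change at the digits printed from compound 1 to compound 4 (within the scatter). Compound 4 is therefore estimated at 400 nM, with a range from 150 nM to 1100 nM.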

Compound 4, half-maximal inhibitory concentration: 54 nM
The estimate for compound 4 lay 7.4-fold (0.87 log units) above the measured number; measured number below the stated range.
By their numbers in this assay, from the lowest: compound 4; then compounds 1 and 2 (each within the scatter of the next); then compound 3.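

Moving the methyl alone, with the same atoms joined differently, gives a 7.4-fold lower number from compound 1 to compound 4 (0.87 log units; beyond the scatter) in this assay. This position therefore responds to how the pyrazole is substituted and not only to its presence, which was all that an 11-fold higher number from compound 2 to compound 3 (1.04 log units; beyond the scatter) could show. The entering 5-methyl-1H-pyrazol-4-yl group carries a hydrogen-bond donor that the leaving 1-methyl-1H-pyrazol-4-yl group lacks, but no evidence at hand ties the step to that difference or to any other origin.

An unsubstituted 1H-pyrazol-4-yl group would help separate the contribution of the ring hydrogen on nitrogen from that of the methyl on carbon. On these data alone, whether the step carries over to the core of compound 2, which lacks the isopropoxy group, also remains open.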